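Thiophene sulfonamide analogue of a long-chain threonine amide

A few compounds are considered here, and "the series" means these few. Any claim that something is new, unique, unknown or untested is made for them only; others in the source may bear on it.

Three compounds share a common core with a long alkyl chain on one amide and differ in the group on the amine nitrogen. Compound 1 `CCCCCCCCCCCCCCCCCCNC(=O)[C@@H](NC(=O)c1cccs1)[C@@H](C)O` carries a thiophene carbonyl and gives 25700 nM in a functional assay on MCF7 cells (Homo sapiens) for cytotoxicity, read by MTT assay, with a stated time of 48 h; a lower number here means a stronger inhibitor, a higher number a weaker inhibitor. Compound 2 `CCCCCCCCCCCCCCCCCCNC(=O)[C@@H](NC(=O)c1cc2ccccc2o1)[C@@H](C)O` carries a benzofuran carbonyl and gives 126000 nM. Compound 3 `CCCCCCCCCCCCCCCCCCNC(=O)[C@@H](NS(=O)(=O)c1ccc(C)cc1)[C@@H](C)O` carries a tolylsulfonyl and gives 60100 nM, the second highest of the three numbers. The steps measured so far are a 4.9-fold higher number from compound 1 to compound 2 (0.69 log units; beyond the scatter), a 2.3-fold higher number from compound 1 to compound 3 (0.37 log units; beyond the scatter) and a 2.1-fold lower number from compound 2 to compound 3 (0.32 log units; beyond the scatter), each a modest move. Compound 4 `CCCCCCCCCCCCCCCCCCNC(=O)[C@@H](NS(=O)(=O)c1cccs1)[C@@H](C)O` differs from compound 3 by thiophen-2-yl in place of 4-methylphenyl on a sulfonyl sulfur, making it the sulfonyl counterpart of compound 1. Among the measured compounds shown here, no measured step exchanges rings on a sulfonyl sulfur, so the nearest guide is the thiophene-carbonyl compound 1 standing lowest and the carbonyl-to-sulfonyl move seen from compound 1 to compound 3. Taken together a small move is expected, a 1.3-fold lower number from compound 3 to compound 4 (0.13 log units; within the scatter), and compound 4 is estimated at 45000 nM with a range from 15000 nM to 130000 nM.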

Compound 4, half-maximal inhibitory concentration: > 200000 nM
Compound 4 was reported as a limit; the forecaster's own chance of this, stated with the estimate: 10%; middle value at least 4.4-fold (0.64 log units) away from the limit.
By their numbers in this assay, from the lowest: compound 1; then compound 3; then compound 2. At a limit, above all of these: compound 4.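

In this assay compound 4 is reported only as a limit, > 200000 nM, and not as a number. Among the compounds shown here, on the sulfonyl sulfur, the exchange of 4-methylphenyl for thiophen-2-yl gives an at least 3.3-fold higher number from compound 3 to compound 4 (0.52 log units; beyond the scatter), which shows that the ring on this sulfur can move the number, something no earlier step could show. The thiophene ring that stood lowest as a carbonyl compound does not keep that place as a sulfonyl compound, with an at least 7.7-fold higher number from compound 1 to compound 4 (0.89 log units; beyond the scatter), and the comparison with the benzofuran carbonyl stays loose, at an at least 1.5-fold higher number from compound 2 to compound 4 (0.20 log units; that floor lies within the scatter).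

From the compounds shown here alone, whether a plain phenyl, a 4-methoxyphenyl or a pyridine ring on the sulfonyl sulfur would stand with compound 3 or with compound 4 remains open. So does whether a shorter alkyl chain on the amide would alter these steps.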